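A few compounds are considered here, and "the series" means these few. Any claim that something is new, unique, unknown or untested is made for them only; others in the source may bear on it.

Compound 1 `C#CCN1CCN(c2cccc3[nH]c(-c4ccc(C(C)(C)C)cc4)nc23)CC1` is the starting point of this account. In a functional assay on cells for antagonist activity at Gonadotropin-releasing hormone receptor (Homo sapiens), read by FLIPR and calcium flux, with a stated time of 15 min (on this read-out higher numbers stand for weaker inhibition and lower numbers for stronger inhibition), compound 1 gives 20000 nM, the higher of the two numbers recorded, with the number of compound 3 well apart from it, beyond the usual scatter. Compound 3 `COc1cc(OC)c(NC(=O)c2ccc(Cc3cc4c(cc3C)C(C)(C)CCC4(C)C)o2)c(OC)c1`, built on a different core, gives 1000 nM in this assay. Among the compounds with values here, compound 2 `CC(C)(C)c1ccc(-c2nc3c(N4CCN(Cc5cn([C@@H]6O[C@H](CO)[C@@H](O)[C@H](O)[C@H]6O)nn5)CC4)cccc3[nH]2)cc1` is reported in this assay only as > 10000 nM, which is a limit of the assay and not a number, and it is the one value that sits at the limit of > 10000 nM in this assay, at which 1 of the 3 values shown sits.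

Compound 4 `CC(C)(C)c1ccc(-c2nc3c(N4CCN(Cc5cccc6nccnc56)CC4)cccc3[nH]2)cc1` has not yet been measured. It keeps the core of compound 1 and differs from it in one place: quinoxalin-5-yl in place of ethynyl on a saturated chain carbon bound to an amine nitrogen in a ring. Propargyl becomes (quinoxalin-5-yl)methyl on the saturated chain carbon bound to the amine nitrogen in the ring. Within the data shown here, with no measured step of this kind to lean on, the author expects a moderate gain in potency, a step from compound 1 to compound 4 of an 8.0-fold lower number from compound 1 to compound 4 (0.90 log units; beyond the scatter) in this assay. For compound 4 the estimated value in this assay is 2500 nM, within a range of 300 nM to 15000 nM.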

Compound 4, half-maximal inhibitory concentration: 631 nM
Compound 4: middle estimate off by 4.0-fold (0.60 log units), on the high side; the measured number falls inside the stated range.
By their numbers in this assay, from the lowest: compounds 4 and 3 (each within the scatter of the next); then compound 1.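

On the shared core, the saturated chain carbon bound to an amine nitrogen in a ring proves able to carry a much larger group than earlier data showed: quinoxalin-5-yl in place of ethynyl gives a 32-fold lower number from compound 1 to compound 4 (1.50 log units; beyond the scatter) in this assay. Within the data shown here, this is the first measured step at this place, and it shows that potency here responds strongly to what the chain carbon bears. A large group alone does not settle the outcome, however, since compound 2, which carries a different large group at this place, is reported only as a limit: the limit of > 10000 nM in this assay, at which 1 of the 4 values shown sits.

On these data alone, what remains open is whether a plain phenyl or a pyridine ring on the same chain carbon would give a similar step. As far as these compounds go, it is also open whether the gain depends on the two ring nitrogens of quinoxalin-5-yl or on its two aromatic rings.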